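This account rests on a few compounds, and the source may have more. Where it says the series, first, only, none or still open, it means among the compounds named here.

Compounds measured in an ADME assay on MOLT-3 cells (Homo sapiens) for cytotoxicity, with a stated time of 7 days; a lower number here means that less compound is tolerated, a higher number that more compound is tolerated: compound 1 `CCCNc1nc(N)nc2c1ncn2/C=C1/CC1(CO)CO`, "not determined" (no result reported), and compound 3 `Nc1nc(N2CCCC2)c2ncn(/C=C3/CC3(CO)CO)c2n1`, "not determined" (no result reported). Compound 2 `CCCCNc1nc(N)nc2c1ncn2/C=C1/CC1(CO)CO` gives > 20000 nM, which is a limit of the assay rather than a number, (the limit of > 20000 nM in this assay, at which 1 of the 3 values shown sits).

Compound 1 therefore stands without a number of its own in this assay; of the other two entries, one is a limit and the other has no number either. Compound 4 `CC(C)Sc1nc(N)nc2c1ncn2/C=C1/CC1(CO)CO` differs from compound 1 in one place: isopropylsulfanyl in place of propylamino on an aromatic carbon. Within the data shown here, no step between measured compounds is available, so the size of the change from compound 1 to compound 4 cannot be read from the data; the expectation is for no step beyond the usual scatter. Compound 4 is expected near 25000 nM, within 8000 nM to 80000 nM, quite possibly reported only as a limit.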

Compound 4, half-maximal cytotoxic concentration: > 20000 nM
Compound 4: no number, only a limit (the forecaster's own chance of this, stated with the estimate: 70%); the middle value does not contradict the limit.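

Compound 2 and compound 4 each give only a limit, so no step between them can be read: the limit of > 20000 nM in this assay, at which 2 of the 4 values shown sit.

The compounds shown leave open what actual numbers compound 2 and compound 4 would have, and where compound 1 and compound 3 stand.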